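The source may report more compounds than this note shows. Statements on the series, on what has been measured and on what is new or still open speak of the compounds shown alone.

Compound 2 `Cc1ccc(C(CCN(C)C)NC(=O)CCc2ccc(C(F)(F)F)cc2)cc1` stands lowest of the two numbers at hand: in a functional assay on NIH3T3 cells for agonist activity at Urotensin-2 receptor (Homo sapiens), with a stated time of 5 days (on this read-out higher numbers stand for larger maximal responses and lower numbers for smaller maximal responses), compound 2 gives 60%, whereas compound 1 `COc1ccc(CCC(=O)NC(CCN(C)C)c2ccc3ccccc3c2)cc1` gives 113%, a gap beyond the scatter. Compound 3 `CN(C)CCC(NC(=O)CCc1ccc(C(F)(F)F)cc1)c1ccc2ccccc2c1` has not yet been measured in this assay. It differs from compound 2 in one place: naphthalen-2-yl in place of 4-methylphenyl on a saturated chain carbon bound to an amide-type nitrogen and a saturated chain carbon. Among the compounds with values here, no measured pair isolates this change. Compound 1, which carries naphthalen-2-yl, gives 113%, so a rise beyond the scatter is expected, and the step is estimated as a number 30 percentage points higher from compound 2 to compound 3 (beyond the scatter). Compound 3 is therefore expected to reach about 90%, within a range of 60% to 115%.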

Compound 3, largest response reached (reported as efficacy), in percent of the reference or control that the assay uses: 75%
Compound 3: the middle estimate sits 15 percentage points above what was measured; the range from low to high includes it.
By their numbers in this assay, from the lowest: compound 2; then compound 3; then compound 1.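

On the saturated chain carbon bound to an amide-type nitrogen and a saturated chain carbon, naphthalen-2-yl in place of 4-methylphenyl gives a number 15 percentage points higher from compound 2 to compound 3 (beyond the scatter) in this assay, so this position responds to the change, though modestly. With naphthalen-2-yl held fixed, trifluoromethyl in place of methoxy on an aromatic carbon gives a number 38 percentage points lower from compound 1 to compound 3 (beyond the scatter), a large step that shows the aromatic substituent also weighs heavily on the response. No evidence at hand explains either step. As far as these compounds go, it remains open how a plain phenyl or a pyridine ring would fare at the chain carbon, and whether the step from methoxy to trifluoromethyl would hold with 4-methylphenyl there.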